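This account rests on a few compounds, and the source may have more. Where it says the series, first, only, none or still open, it means among the compounds named here.

Measured compounds:
compound 1 `N#CC1=C(N)Oc2c(c3nc4ccccc4nc3c3ccccc23)C12C(=O)N(Cc1cnnn1-c1ccc(F)cc1)c1ccccc12`: > 50000 nM
compound 2 `Cc1ccc(-n2nncc2CN2C(=O)C3(C(C#N)=C(N)Oc4c3c3nc5ccccc5nc3c3ccccc43)c3ccccc32)cc1C`: > 50000 nM

In an ADME assay on HUVEC cells (Homo sapiens) for antiproliferative activity, read by MTT assay, with a stated time of 48 h (on this read-out lower numbers stand for stronger inhibition and higher numbers for weaker inhibition), compound 1 gives > 50000 nM, which is a limit of the assay and not a number. Compound 2 gives > 50000 nM in the same assay, again a limit rather than a number. For the measured compounds named here, the only measured step is a step that the two limits leave unreadable from compound 1 to compound 2; with both ends at a limit, its size cannot be read. Where compound 1 stands is therefore known only as a limit, and the one further value shown is a limit too, because of the limit of > 50000 nM in this assay, at which 2 of the 2 values shown sit.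

Compound 3 `Cc1ccc(Cl)cc1-n1nncc1CN1C(=O)C2(C(C#N)=C(N)Oc3c2c2nc4ccccc4nc2c2ccccc32)c2ccccc21` has not yet been measured. It differs from compound 1 in one place: 5-chloro-2-methylphenyl in place of 4-fluorophenyl on an aromatic nitrogen. Going by the values given here, the one step that bears on this change, from compound 1 to compound 2, is unreadable, so it gives neither size nor direction, and nothing in the data sets compound 3 apart from compounds 1 and 2. Compound 3 is therefore expected to stay at the limit in this assay, the step being estimated as a step that the limit leaves unreadable from compound 1 to compound 3. The estimate for compound 3 is 80000 nM, with a range from 50000 nM to 200000 nM, and a limit rather than a number is the likely report.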

Compound 3, half-maximal inhibitory concentration: > 50000 nM
Compound 3 ended at the assay's limit (the forecaster's own chance of this, stated with the estimate: 90%); the middle value is on the limit's open side.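

In this assay compound 3 gives > 50000 nM, a limit and not a number. The steps linking compound 3 to compound 1 and compound 2 cannot be read, because all three compounds stop at the same limit: the limit of > 50000 nM in this assay, at which 3 of the 3 values shown sit.

The compounds shown leave open how far each lies past that limit, and whether changing the group on this aromatic nitrogen alters the read-out at all.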